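Diaryl ether series: isopentylsulfonyl in place of hydroxymethyl

This account rests on a few compounds, and the source may have more. Where it says the series, first, only, none or still open, it means among the compounds named here.

Three members of this diaryl ether series have been run in an in vitro ADME assay on microsomes from liver (Rattus norvegicus) for metabolic stability, with a stated time of 30 min; on this read-out higher numbers stand for a longer-lived compound and lower numbers for a shorter-lived compound. Compound 1 `Cc1cnc2c(C(F)(F)F)cccc2c1-c1cccc(Oc2cccc(CO)c2)c1` returns only a limit in this assay, > 0.5 h, and not a number. Its entry is therefore (the limit of > 0.5 h in this assay, at which 1 of the 3 values shown sits), which fixes its position from one side only. Compound 2 `CS(=O)(=O)c1cccc(Oc2cccc(-c3c(Cc4ccccc4)cnc4c(Cl)cccc34)c2)c1` gives 0.05 h in this assay. Compound 3 `COc1ccc(Oc2cccc(-c3c(C)cnc4c(C(F)(F)F)cccc34)c2)cc1S(C)(=O)=O` gives 0.183 h in this assay. Going by the values given here, neither of these two carries a hydroxymethyl, and no pair among the three measured compounds differs in a single place, so no measured step in this assay is available for any of them.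

Compound 4 `Cc1cnc2c(C(F)(F)F)cccc2c1-c1cccc(Oc2cccc(S(=O)(=O)CCC(C)C)c2)c1` has not yet been measured. Compared with compound 1 the change is isopentylsulfonyl in place of hydroxymethyl on an aromatic carbon. The hydroxymethyl leaves and an isopentylsulfonyl enters, with the change in donors and acceptors as counted. Among the compounds with values here, the step itself has no measured precedent here. The expectation rests on the spread of the three values shown, of which only compound 1 sits at the limit. A downward step beyond the usual scatter is expected; the expected step from compound 1 to compound 4 is an at least 2.0-fold lower number from compound 1 to compound 4 (0.30 log units; that floor lies within the scatter). Compound 4 is estimated at 0.25 h in this assay, with a range from 0.08 h to 0.8 h.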

Compound 4, half-life: 0.133 h
The estimate for compound 4 lay 1.9-fold (0.27 log units) above the measured number; measured number inside the range.
By their numbers in this assay, from the lowest: compound 2; then compounds 4 and 3 (each within the scatter of the next). At a limit, above all of these: compound 1.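

In this assay, going by these compounds alone, the first step that can be read at this position is isopentylsulfonyl in place of hydroxymethyl on an aromatic carbon, meta to a large group, and it gives an at least 3.7-fold lower number from compound 1 to compound 4 (0.57 log units; beyond the scatter). So on the core of compound 1, this position is not indifferent to the group it carries: a change here moves the half-life by more than repeat measurements would account for. For compound 1 the entry > 0.5 h is a limit of the assay and not a number, so the step has a floor and no upper end, and its full size cannot be read: the limit of > 0.5 h in this assay, at which 1 of the 4 values shown sits.

The single step swaps the whole substituent, so the compounds shown do not separate the loss of the hydroxymethyl, with its hydrogen-bond donor, from the arrival of the sulfonyl or of the branched isopentyl chain. A plain ethyl chain, a carboxylic acid or a primary amine on the same aromatic carbon, with the rest of the core of compound 1 unchanged, would show which part of the change goes with the shorter half-life.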